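The source may hold more compounds than are shown below. What is called first, only, known or untested is meant among the compounds shown, and "the series" means these compounds.

Among the compounds with values here, compound 2 `COc1ccccc1N1CCN(CCCNC(=O)CCc2c[nH]c3ccccc23)CC1` gives the higher of the two numbers so far, 34.7 nM in an assay on isolated protein (thoracic aorta, strain Sprague-Dawley) for antagonist activity at Alpha-1D adrenergic receptor (Rattus norvegicus), with a stated time of 20 min; on this read-out lower numbers stand for tighter binding and higher numbers for weaker binding; compound 1 `COc1ccccc1N1CCN(CCCNC(=O)Cc2c[nH]c3ccccc23)CC1` gives 5.25 nM in this assay. Compound 3 `COc1ccccc1N1CCN(CCCNC(=O)CCCc2c[nH]c3ccccc23)CC1` carries (1H-indol-3-yl)methyl in place of 1H-indol-3-yl on a saturated chain carbon, two bonds along the chain from a carbonyl carbon. Within the data shown here, the only measured step that bears on this change is a 6.6-fold higher number from compound 1 to compound 2 (0.82 log units; beyond the scatter), a modest weakening that lengthened the same chain by one carbon. A further lengthening is therefore expected to weaken binding again, though not necessarily by as much, so compound 3 is estimated at a 2.3-fold higher number from compound 2 to compound 3 (0.36 log units; beyond the scatter), giving an expected 80 nM with a range from 30 nM to 250 nM.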

Compound 3, dissociation constant: 5.13 nM
For compound 3 the middle estimate is 16-fold (1.19 log units) above the measured one, and the stated range ends above it.
By their numbers in this assay, from the lowest: compounds 3 and 1 (each within the scatter of the next); then compound 2.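

In this assay the same one-carbon lengthening that had raised the number now gives a 6.8-fold lower number from compound 2 to compound 3 (0.83 log units; beyond the scatter) and so reverses the direction seen before. The effect of chain length at this position therefore does not run one way, and compound 1 at 5.25 nM and compound 3 at 5.13 nM lie within the scatter of each other. Nothing available accounts for this reversal.

From the compounds shown here alone, whether a longer chain would keep this level of binding remains open. So does the effect of an ether oxygen or an amine placed in the chain.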